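Replacing piperidine with benzylamine in a weak amide series

A few compounds are considered here, and "the series" means these few. Any claim that something is new, unique, unknown or untested is made for them only; others in the source may bear on it.

Compound 1 (`CCCCc1oc2ccccc2c1C(=O)c1ccc(OCC(=O)N2CCCCC2)cc1`) is the starting point of this step. In a functional assay on MDA-MB-231 cells (Homo sapiens) for antiproliferative activity, read by MTT assay, with a stated time of 24 h (a higher number here means a weaker inhibitor, a lower number a stronger inhibitor), compound 1 gives > 50000 nM, which is a limit of the assay and not a number. Its position is therefore known only as the limit of > 50000 nM in this assay, at which 1 of the 2 values shown sits. Among the measured compounds shown here, compound 2 (`CCCCc1oc2ccccc2c1C(=O)c1ccc(OCC(=O)N2CCN(C(=O)OC(C)(C)C)CC2)cc1`) provides the only numerical reading so far, with compound 2 at 36900 nM.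

Compound 3 (`CCCCc1oc2ccccc2c1C(=O)c1ccc(OCC(=O)NCc2ccccc2)cc1`) has benzylamino in place of piperidin-1-yl on a carbonyl carbon. The rest of the structure matches compound 1.

For the measured compounds named here, no measured pair shows the size of this kind of change. The expectation therefore rests on little evidence. In this assay, a modest shift towards a stronger inhibitor is expected, with compound 3 remaining weak. Going by the values given here, the only anchor is compound 2 at 36900 nM, so the estimate stays in that region. Another limit reading remains quite possible for compound 3. The expected size of the change is an at least 1.7-fold lower number from compound 1 to compound 3 (0.25 log units; that floor lies within the scatter). Compound 3 is estimated at 28000 nM, with an expected range from 10000 nM to 50000 nM.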

Compound 3, half-maximal inhibitory concentration: > 50000 nM
Compound 3 gave a limit, no number; the forecaster's own chance of this, stated with the estimate: 35%; at least 1.7-fold (0.25 log units) between middle value and limit.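

In this assay, compound 1 and compound 3 both end at a limit of the assay and not a number, so no step can be read between them: the limit of > 50000 nM in this assay, at which 2 of the 3 values shown sit.

The compounds shown leave open whether benzylamino in place of piperidin-1-yl on a carbonyl carbon changes the reading at all, and in which direction.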